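This account rests on a few compounds, and the source may have more. Where it says the series, first, only, none or still open, it means among the compounds named here.

Measured compounds in an assay on isolated protein for inhibition of vitamin D3 receptor (Homo sapiens); a lower number here means a stronger inhibitor, a higher number a weaker inhibitor:
- compound 1 `N=c1scc(-c2ccccc2)n1CC(=O)N1CCN(c2ccccc2)CC1`: 1600 nM
- compound 2 `N=c1scc(-c2ccccc2)n1CC(=O)N1CCOCC1`: 24400 nM
- compound 3 `Cc1ccc(-c2csc(=N)n2CC(=O)N2CCN(c3ccccc3)CC2)cc1`: 1030 nM

Compound 3 holds the lowest of the three numbers in this assay. Its nearest neighbour is compound 1, the step of a 1.6-fold lower number from compound 1 to compound 3 (0.19 log units; within the scatter) lying within the scatter, so the two are not separated. Compound 2 stands far from it, its value beyond the scatter relative to compound 3.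

Compound 4 `CC(=O)N1CCN(C(=O)Cn2c(-c3ccc(C)cc3)csc2=N)CC1` is not yet measured. It differs from compound 3 in one place: acetyl in place of phenyl on an amine nitrogen in a ring.

Among the measured compounds shown here, no measured single-place step covers an acetyl replacing the phenyl on that ring nitrogen. For the measured compounds named here, the only pair that informs the question is compound 1 against compound 2, which differ in more than one place and so carry no computed step; their values show that the analogue without the phenyl on the saturated ring, compound 2, gives 24400 nM, against compound 1 at 1600 nM. Since compound 4 also loses that phenyl, a markedly higher number is expected, the step of a 15-fold higher number from compound 3 to compound 4 (1.16 log units; beyond the scatter) being the expected size. Compound 4 is therefore estimated at 15000 nM, with a range of 4000 nM to 50000 nM.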

Compound 4, inhibition constant: 2840 nM
Beside the measured number, compound 4's estimate is 5.3-fold (0.72 log units) above it; measured number outside the range, below it.
By their numbers in this assay, from the lowest: compounds 3, 1 and 4 (each within the scatter of the next, the first and the last beyond it); then compound 2.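

In this assay, among the compounds shown here, the step of a 2.8-fold higher number from compound 3 to compound 4 (0.44 log units; beyond the scatter) is the first single-place change at the amine nitrogen of the six-membered ring with 2 nitrogen, and it is modest though beyond the scatter. The phenyl on this nitrogen is therefore not required for a number of this order: acetyl, which has no ring and brings a hydrogen-bond acceptor, takes its place at a small cost, so this position tolerates a change in both the size and the type of group, at least on the core of compound 3. The compounds shown offer no measurement that explains why this step is small, so the change can only be described, not accounted for.

From the compounds shown here alone, it remains open whether the small cost is specific to acetyl or extends to other groups on this nitrogen, such as a methyl, a benzyl, a pyridyl, a methanesulfonyl or a plain hydrogen. Also open, going by these compounds, is whether the step keeps its size when acetyl replaces the phenyl in compound 1, which lacks the methyl on the other aromatic ring.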